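Replacing a Dimethoxyphenyl Ketone with a Pyrrol-2-yl Ketone

A few compounds are considered here, and "the series" means these few. Any claim that something is new, unique, unknown or untested is made for them only; others in the source may bear on it.

Compound 1 `COc1ccc(-c2cc3ccccc3nc2/C=C/C(=O)c2ccccc2)cc1` in a functional assay on NCI-H1299 cells (Homo sapiens) for antiproliferative activity, read by XTT assay, with a stated time of 72 h (on this read-out higher numbers stand for weaker inhibition and lower numbers for stronger inhibition), gives 1410 nM. Compound 2 `COc1ccc(-c2cc3ccccc3nc2/C=C/C(=O)c2ccc(O)cc2)cc1` gives 8970 nM. Compound 3 `COc1ccc(-c2cc3ccccc3nc2/C=C/C(=O)c2c(OC)cccc2OC)cc1` gives 4710 nM.

Among these three numbers compound 3 stands second highest; its nearest neighbour is compound 2, with a 1.9-fold lower number from compound 2 to compound 3 (0.28 log units; within the scatter), and its furthest is compound 1, with a 3.3-fold higher number from compound 1 to compound 3 (0.52 log units; beyond the scatter). Compound 4 `COc1ccc(-c2cc3ccccc3nc2/C=C/C(=O)c2ccc[nH]2)cc1` differs from compound 3 in one place: 1H-pyrrol-2-yl in place of 2,6-dimethoxyphenyl on a carbonyl carbon. For the measured compounds named here, no measured step introduces this ring, so only indirect guidance exists. Going by the values given here, the steps that bear on the ketone aryl group are a 3.3-fold higher number from compound 1 to compound 3 (0.52 log units; beyond the scatter) and a 6.4-fold higher number from compound 1 to compound 2 (0.80 log units; beyond the scatter), both modest weakenings away from the plain phenyl ketone, while a 1.9-fold lower number from compound 2 to compound 3 (0.28 log units; within the scatter) shows that two substituted aryl ketones sit within the scatter of each other. A five-membered ring carrying one hydrogen-bond donor lies outside what the three measured ketones cover, so the direction remains uncertain. Compound 4 is therefore expected to show a 1.3-fold lower number from compound 3 to compound 4 (0.13 log units; within the scatter), a step within or close to the scatter. For compound 4 the estimated value is 3500 nM, with a range from 1000 nM to 12000 nM.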

Compound 4, half-maximal inhibitory concentration: > 10000 nM
Compound 4 gave a limit, no number; the forecaster's own chance of this, stated with the estimate: 5%; at least 2.8-fold (0.45 log units) between middle value and limit.
By their numbers in this assay, from the lowest: compound 1; then compounds 3 and 2 (each within the scatter of the next). At a limit, above all of these: compound 4.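

In this assay compound 4 gives > 10000 nM, which is a limit of the assay and not a number. The 1H-pyrrol-2-yl ring is the only five-membered ring shown on this carbonyl carbon, and it does not keep the level of the phenyl or 2,6-dimethoxyphenyl ketones: an at least 7.0-fold higher number from compound 1 to compound 4 (0.85 log units; beyond the scatter) and an at least 2.1-fold higher number from compound 3 to compound 4 (0.32 log units; beyond the scatter), both at least modest. Against the 4-hydroxyphenyl ketone the step gives only a floor, an at least 1.1-fold higher number from compound 2 to compound 4 (0.04 log units; that floor lies within the scatter), so those two ketones cannot be put in order.

The compounds shown leave open whether the loss follows the ring hydrogen on nitrogen or the five-membered ring itself. A 1-methylpyrrol-2-yl, furan-2-yl or thiophen-2-yl ketone would separate these two readings.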